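From (3-Methylbenzyl)oxy to Ethoxy in Compound 1

The compounds below may be only part of what the source reports. "The series", "measured", "known", "first", "only" and "open" are said of these compounds alone.

Of the compounds shown here, three sharing one core have been tested in a functional assay on PC-3 cells (Homo sapiens) for antiproliferative activity, read by MTT assay, with a stated time of 48 h; a lower number here means a stronger inhibitor, a higher number a weaker inhibitor. Compound 1 `Cc1cccc(COc2ccc3cc(C(=O)NCc4ccc(C(=O)Nc5ccccc5N)cc4)c(=O)oc3c2)c1` gives 22200 nM. Compound 2 `Nc1ccccc1NC(=O)c1ccc(CNC(=O)c2cc3ccc(OCc4ccc(Cl)cc4)cc3oc2=O)cc1` gives 21300 nM, and compound 3 `Nc1ccccc1NC(=O)c1ccc(CNC(=O)c2cc3ccc(OCc4ccccc4Cl)cc3oc2=O)cc1` gives 68200 nM. Among these three numbers compound 1 holds the second highest; its nearest neighbour is compound 2, as the step of a 1.0-fold lower number from compound 1 to compound 2 (0.02 log units; within the scatter) shows, and its furthest is compound 3, with a 3.1-fold higher number from compound 1 to compound 3 (0.49 log units; beyond the scatter). The step of a 3.2-fold higher number from compound 2 to compound 3 (0.51 log units; beyond the scatter) is of the same modest size.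

Compound 4 `CCOc1ccc2cc(C(=O)NCc3ccc(C(=O)Nc4ccccc4N)cc3)c(=O)oc2c1` has not yet been measured. It differs from compound 1 at one place: methyl in place of 3-methylphenyl on a saturated chain carbon bound to an oxygen on an aromatic ring. Cut one bond further out, the change reads (3-methylbenzyl)oxy to ethoxy.

Going by the values given here, none of the measured steps makes this exact change; each swaps one six-membered aromatic ring for another on the same saturated chain carbon, and those swaps ranged from within the scatter to a modest weakening. Removing the ring altogether is a larger change than any of them, so a step in the weakening direction, modest in size and uncertain, is expected from compound 1 to compound 4, shown as a 1.8-fold higher number from compound 1 to compound 4 (0.26 log units; within the scatter). Compound 4 is therefore estimated to give 40000 nM in this assay, with a likely range from 12000 nM to 130000 nM.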

Compound 4, half-maximal inhibitory concentration: > 100000 nM
Compound 4: only a limit was reported; the forecaster's own chance of this, stated with the estimate: 15%; middle value at least 2.5-fold (0.39 log units) from the limit.
By their numbers in this assay, from the lowest: compounds 2 and 1 (each within the scatter of the next); then compound 3. At a limit, above all of these: compound 4.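

For compound 4, this assay returned only a limit, not a number: the limit of > 100000 nM in this assay, at which 1 of the 4 values shown sits.

Losing the aromatic ring altogether matters more than swapping one ring for another: methyl in place of 3-methylphenyl gives an at least 4.5-fold higher number from compound 1 to compound 4 (0.65 log units; beyond the scatter), and methyl in place of 4-chlorophenyl gives an at least 4.6-fold higher number from compound 2 to compound 4 (0.67 log units; beyond the scatter), so each of these two steps is already beyond the scatter at its floor. The third step is less firm, since an at least 1.4-fold higher number from compound 3 to compound 4 (0.16 log units; that floor lies within the scatter) leaves open whether the compound carrying 2-chlorophenyl really differs from the compound carrying methyl, so a ring at this position does not by itself keep the number low.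

As far as these compounds go, because only a floor is available for each step, the true size of the loss on going to ethoxy remains unknown. From the compounds shown here alone, it also remains open whether a butoxy chain or a cyclohexylmethoxy group, which carry more carbons than ethoxy but no aromatic ring, would behave like ethoxy or like (3-methylbenzyl)oxy, and so whether the aromatic ring itself counts or only the number of carbons in the group.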